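Moving a Fluorine on the Aryl Ring: Compound 1 to Compound 4

This account rests on a few compounds, and the source may have more. Where it says the series, first, only, none or still open, it means among the compounds named here.

Of the compounds shown here, three have been measured in a functional assay on HT-29 cells (Homo sapiens) for antiproliferative activity, read by sulforhodamine B assay, with a stated time of 72 h; a higher number here means a weaker inhibitor, a lower number a stronger inhibitor. Compound 1 `Fc1cccc(NC(=S)N/N=C/c2ccc3ccccc3n2)c1` gives 74700 nM, the highest number of the three. Compound 2 `Cc1csc2sc(/C=N/NC(N)=S)c(C)c12` gives 57500 nM, which lies within the scatter of compound 1. Compound 3 `CC(C)c1cccc(C(C)C)c1NC(=S)N/N=C/c1ccc2ccccc2n1` gives 20700 nM, a lower number than compound 1 by a margin beyond the scatter. Compound 4 `Fc1ccccc1NC(=S)N/N=C/c1ccc2ccccc2n1` has not yet been measured. It differs from compound 1 in one place: 2-fluorophenyl in place of 3-fluorophenyl on an amide-type nitrogen. For the measured compounds named here, no measured pair shows a change of this kind, so nothing in the data points to a direction. A small step is expected, in no clear direction, most likely within the scatter. Compound 4 is therefore estimated at 70000 nM, with a range from 30000 nM to 170000 nM. This estimate means an expected step of a 1.1-fold lower number from compound 1 to compound 4 (0.03 log units; within the scatter).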

Compound 4, half-maximal inhibitory concentration: > 100000 nM
Compound 4: a limit, no number (the forecaster's own chance of this, stated with the estimate: 20%); middle value at least 1.4-fold (0.15 log units) away from the limit.
By their numbers in this assay, from the lowest: compound 3; then compounds 2 and 1 (each within the scatter of the next). At a limit, above all of these: compound 4.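

Moving the fluorine gives the first one-place comparison here. In this assay compound 4 gives > 100000 nM, which is a limit of the assay and not a number. Placing 2-fluorophenyl in place of 3-fluorophenyl on the amide-type nitrogen gives an at least 1.3-fold higher number from compound 1 to compound 4 (0.12 log units; that floor lies within the scatter), so this change shows no sign of stronger inhibition, and its full size cannot be read: the limit of > 100000 nM in this assay, at which 1 of the 4 values shown sits.

The compounds shown leave open how far compound 4 lies past that limit. They also leave open whether an unsubstituted phenyl or a methoxyphenyl on the same nitrogen would give a lower number.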